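A few compounds are considered here, and "the series" means these few. Any claim that something is new, unique, unknown or untested is made for them only; others in the source may bear on it.

In a functional assay on A-375 cells (Homo sapiens) for cytotoxicity, read by CCK-8 assay, with a stated time of 24 h (a lower number here means a stronger inhibitor, a higher number a weaker inhibitor), compound 1 `COc1ccccc1Oc1c(N)nc(-c2ccccc2)nc1Cl` gives 7220 nM. Compound 3 `COc1ccccc1Oc1c(N)nc(-c2ccc(Cl)cc2)nc1Cl`, which carries 4-chlorophenyl in place of the phenyl group, gives 1030 nM, so compound 1 holds the higher of the two true numbers in this small set. Compound 2 `COc1ccccc1Oc1c(N)nc(-c2ccccc2F)nc1Cl`, which carries 2-fluorophenyl instead, is recorded at > 80000 nM, and this is a limit, not a number.

Small edits on that phenyl group therefore matter a great deal: the set shows an at least 11-fold higher number from compound 1 to compound 2 (1.04 log units; beyond the scatter), then a 7.0-fold lower number from compound 1 to compound 3 (0.85 log units; beyond the scatter), and also an at least 77-fold lower number from compound 2 to compound 3 (1.89 log units; beyond the scatter).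

Compound 4 `COc1ccccc1Oc1c(N)nc(-c2ccccc2)nc1OCCO` is changed at a different place, with 2-hydroxyethoxy in place of chloro on an aromatic carbon. Within the data shown here, no measured step touches this place, so the data give no direct guide to the effect of this swap. They bear on it only indirectly: compound 2 and compound 3 show, through the steps above, that one change can move the number of compound 1 far in either direction. The swap is also larger than either of those edits, so a wide range is warranted, and a rise is expected only tentatively. The estimated change is a 2.2-fold higher number from compound 1 to compound 4 (0.35 log units; beyond the scatter), with its direction uncertain. For compound 4 the expected value in this assay is 16000 nM, with an estimated range from 3000 nM to 70000 nM.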

Compound 4, half-maximal inhibitory concentration: > 80000 nM
Compound 4: only a limit was reported; the forecaster's own chance of this, stated with the estimate: 20%; at least 5.0-fold (0.69 log units) between middle value and limit.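

Until now every measured change lay on the phenyl group, whereas this one lies on the aromatic carbon next to the ring nitrogen, and it shows that this place matters too: in this assay, 2-hydroxyethoxy in place of chloro gives an at least 11-fold higher number from compound 1 to compound 4 (1.04 log units; beyond the scatter). Compound 4 is recorded at > 80000 nM, which is a limit and not a number. The step is therefore only a floor, so the data show that activity falls sharply with this swap but not how far, and this ceiling of the read-out has now been reached by more than one compound: the limit of > 80000 nM in this assay, at which 2 of the 4 values shown sit.

The compounds shown leave open whether the rise comes from losing the chloro or from the 2-hydroxyethoxy chain itself, and a single swap cannot separate the two. A bromo or an ethoxy group at this place, or a longer chain ending in an amine, would help show whether anything other than chloro can keep a measurable number here.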